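A few compounds are considered here, and "the series" means these few. Any claim that something is new, unique, unknown or untested is made for them only; others in the source may bear on it.

Three compounds have been measured in a functional assay on L1210 cells (Mus musculus) for antiproliferative activity; a lower number here means a stronger inhibitor, a higher number a weaker inhibitor:

Compound 1, `Cc1nsc2[nH]c(SCc3ccccc3)nc12`, gives 7000 nM.
Compound 2, `c1ccc(CSc2nc3cnsc3[nH]2)cc1`, gives 300 nM.
Compound 3, `CSc1nc2snc(C)c2n1[C@H]1C[C@H](O)[C@@H](CO)O1`, gives 33000 nM.

Compound 1 and compound 2 share one core and differ in a single place: hydrogen in place of methyl on an aromatic carbon. That change made the number in this assay fall, a 23-fold lower number from compound 1 to compound 2 (1.37 log units; beyond the scatter). Compound 3 carries the same methyl on a different core; how the two cores differ is not broken down here. Its number in this assay is the highest of the three, so the weakest inhibitor measured so far.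

Compound 4, `CSc1nc2sncc2n1[C@H]1C[C@H](O)[C@@H](CO)O1`, is not yet measured. It differs from compound 3 in exactly the same way, at the same place: hydrogen in place of methyl on an aromatic carbon. Because the step of a 23-fold lower number from compound 1 to compound 2 (1.37 log units; beyond the scatter) was large and the change is the same, a drop of the same kind is expected for compound 4, though with a different core its size is uncertain. The step from compound 3 is estimated as an 11-fold lower number from compound 3 to compound 4 (1.04 log units; beyond the scatter). Compound 4 is therefore expected to give about 3000 nM in this assay, most likely between 600 nM and 15000 nM.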

Compound 4, half-maximal inhibitory concentration: 20000 nM
Compound 4: middle estimate off by 6.7-fold (0.82 log units), on the low side, outside the stated range (above it).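

In this assay, putting hydrogen in place of methyl gives a 1.7-fold lower number from compound 3 to compound 4 (0.22 log units; within the scatter) and so the two cannot be told apart in this measurement. The same change therefore does not carry its size from one core to the other in this series: the same change on two cores in this assay, a 23-fold lower number (1.37 log units; beyond the scatter) from compound 1 to compound 2 and a 1.7-fold lower number (0.22 log units; within the scatter) from compound 3 to compound 4, 14-fold (1.15 log units) apart, beyond the scatter of two such steps

This does not show which feature of the cores is responsible, since the two pairs differ from each other in more than one place, and two pairs give no rule for predicting the step on a third core.

The compounds shown hold only methyl or hydrogen at this place on the ring, so they leave open what an ethyl group, a chlorine atom or an amine there would do on either core. They also leave open which of the parts that separate the two cores decides whether removing the methyl matters.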